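The compounds below may be only part of what the source reports. "The series", "measured", "known", "first", "only" and "open" are said of these compounds alone.

In an ADME assay on L6 cells (Rattus norvegicus) for cytotoxicity, read by resazurin assay, with a stated time of 72 h (on this read-out higher numbers stand for weaker inhibition and lower numbers for stronger inhibition), compound 1 `OC(c1ccc(Cl)cc1)(c1cccnc1)c1ccccc1Cl` gives 61300 nM. Compound 2 `COC(c1ccc(Cl)cc1)(c1cccnc1)c1ccccc1Cl` gives 58700 nM and compound 3 `NC(c1ccc(Cl)cc1)(c1cccnc1)c1ccccc1Cl` gives 76000 nM, so compound 1 cannot be told apart from either. Among the measured compounds shown here, all the measured steps lie at the saturated carbon: a 1.0-fold lower number from compound 1 to compound 2 (0.02 log units; within the scatter), a 1.2-fold higher number from compound 1 to compound 3 (0.09 log units; within the scatter) and a 1.3-fold higher number from compound 2 to compound 3 (0.11 log units; within the scatter), each within the scatter. Compound 4 `OC(c1ccc(Cl)cc1)(c1cccnc1)c1ccccc1Br` leaves that carbon as in compound 1 and differs elsewhere: bromo in place of chloro on an aromatic carbon. For the measured compounds named here, no measured step covers this change, so those small steps are only an indirect guide, and no step beyond the scatter is expected in this assay. The expected step is a 1.1-fold lower number from compound 1 to compound 4 (0.05 log units; within the scatter). For compound 4 the estimated value is 55000 nM, with an expected range from 28000 nM to 100000 nM.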

Compound 4, half-maximal inhibitory concentration: 55200 nM
Compound 4: middle estimate off by 1.0-fold (0.00 log units), on the low side; measured number inside the range.
By their numbers in this assay, from the lowest: compounds 4, 2, 1 and 3 (each within the scatter of the next).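

Among the compounds shown here, compound 4 takes the change away from the saturated carbon, where all the earlier steps lay, and puts it on the aromatic ring: 2-bromophenyl in place of 2-chlorophenyl gives a 1.1-fold lower number from compound 1 to compound 4 (0.05 log units; within the scatter) in this assay. This position therefore tolerates the exchange of one halogen for the other without a step beyond the scatter. No measurement shown bears on the reason for this result.

The compounds shown leave open whether a group other than a halogen at this place, such as an amine or a carboxylic acid, would shift the number beyond the scatter.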